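A few compounds are considered here, and "the series" means these few. Any claim that something is new, unique, unknown or untested is made for them only; others in the source may bear on it.

In a functional assay on KB cells (Homo sapiens) for inhibition (on this read-out lower numbers stand for stronger inhibition and higher numbers for weaker inhibition), three compounds sharing one core have been measured. Compound 1 `CCOC[C@H]1O[C@@H](n2c(Cl)nc3cc(Cl)c(Cl)cc32)[C@H](OC(C)=O)[C@@H]1OC(C)=O` gives 60000 nM, and compound 2 `CC(=O)OC1C(CBr)OC(n2c(Cl)nc3cc(Cl)c(Cl)cc32)C1OC(C)=O` gives 60000 nM. Compound 3 `CCOC[C@H]1OC(n2c(Cl)nc3cc(Cl)c(Cl)cc32)[C@H](O)[C@@H]1O` gives 80000 nM, a number within the scatter of both others, so these measurements do not separate the three compounds. The next compound, compound 4 `O[C@@H]1[C@@H](CF)OC(n2c(Cl)nc3cc(Cl)c(Cl)cc32)[C@@H]1O`, departs from compound 3 by a single change: fluoro in place of ethoxy on a saturated chain carbon bound to a saturated ring carbon. Within the data shown here, no pair of measured compounds differs in only one place, so the data offer no direct measure of this change. The closest guide is the narrow spread of values. Compound 2, at 60000 nM, also carries a different group on that chain carbon than compound 3, at 80000 nM, although the two differ elsewhere as well. On that limited basis, no change beyond the scatter is expected in this assay. The estimated step is a 1.3-fold lower number from compound 3 to compound 4 (0.12 log units; within the scatter). For compound 4, the expected value is 60000 nM, with an estimated range of 25000 nM to 130000 nM.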

Compound 4, half-maximal inhibitory concentration: > 100000 nM
Compound 4: no number, only a limit; the forecaster's own chance of this, stated with the estimate: 25%; middle value at least 1.6-fold (0.22 log units) away from the limit.
By their numbers in this assay, from the lowest: compounds 1, 2 and 3 (each within the scatter of the next). At a limit, above all of these: compound 4.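

In this assay compound 4 reads > 100000 nM, which is a limit of the assay and not a number. Fluoro in place of ethoxy on a saturated chain carbon bound to a saturated ring carbon comes with an at least 1.2-fold higher number from compound 3 to compound 4 (0.09 log units; that floor lies within the scatter), the first direct reading of a single change at this position, which the earlier compounds, all differing in more than one place, could not supply. It shows that, with the rest of the structure held fixed, this exchange of ethoxymethyl for fluoromethyl brings no sign of stronger inhibition, although the floor of the step is too small to show that inhibition actually weakens.

As far as these compounds go, how far the true value of compound 4 lies beyond the limit stays unknown, so the full size of the step cannot be read and the change may be anything from negligible to large. The compounds shown also leave open how an amine, a carboxylic acid or a longer ether chain on that same carbon would read in this assay, and so whether any group there could move the number clearly below the values seen so far.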